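From Fluorophenyl to Methoxyphenyl in a Series of Limits

The source may hold more compounds than are shown below. What is called first, only, known or untested is meant among the compounds shown, and "the series" means these compounds.

Compound 1 `CCC1=C(O)c2c(oc(-c3ccccc3)cc2=O)C(CC)(CC)C1=O` carries a plain phenyl group on the shared core. In a functional assay on KB cells (Homo sapiens) for antiproliferative activity, read by sulforhodamine B assay, with a stated time of 3 days (on this read-out lower numbers stand for an effect already at smaller amounts and higher numbers for an effect only at larger amounts of compound), compound 1 gives > 236 uM, which is a limit and not a number. Compound 2 `CCC1=C(O)c2c(oc(-c3ccc(CBr)cc3)cc2=O)C(CC)(CC)C1=O` gives > 46.5 uM, also a limit. Compound 3 `CCC1=C(O)c2c(oc(-c3cccc(F)c3)cc2=O)C(CC)(CC)C1=O` gives > 56.2 uM, again a limit. So compound 3 has no exact place in the series, and neither do the other two.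

Compound 4 `CCC1=C(O)c2c(oc(-c3ccccc3OC)cc2=O)C(CC)(CC)C1=O` has 2-methoxyphenyl in place of 3-fluorophenyl on an aromatic carbon, next to the ring oxygen: 2-methoxyphenyl in place of 3-fluorophenyl on an aromatic carbon.

The closest measured change, one substituted phenyl replacing another, is a step that the two limits leave unreadable from compound 2 to compound 3. The other two offer no size either: a step that the two limits leave unreadable from compound 1 to compound 2 and a step that the two limits leave unreadable from compound 1 to compound 3. With no readable step to build on, a step that the limit leaves unreadable from compound 3 to compound 4 is the estimated step, and none beyond the usual scatter is expected. Compound 4 is expected to return only a limit as well. For compound 4 the estimate is 60 uM, with an expected range from 25 uM to 220 uM.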

Compound 4, concentration for half-maximal effect: 40.8 uM
The estimate for compound 4 lay 1.5-fold (0.17 log units) above the measured number; low and high end bracket the measured number.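

Compound 4 has the only exact number among the compounds shown in this assay, whereas the steps among compound 1, compound 2 and compound 3 cannot be read. Methoxy in place of hydrogen on the plain phenyl gives an at least 5.7-fold lower number from compound 1 to compound 4 (0.76 log units; beyond the scatter), the first change here with a size beyond the scatter, though that size is only a floor resting on the limit of compound 1: the limit of > 236 uM in this assay, at which 1 of the 4 values shown sits. Against the two other substituted phenyl groups, the floors of an at least 1.3-fold lower number from compound 3 to compound 4 (0.13 log units; that floor lies within the scatter) and an at least 1.1-fold lower number from compound 2 to compound 4 (0.05 log units; that floor lies within the scatter) stay within the scatter, so 2-methoxyphenyl cannot be ranked against 3-fluorophenyl or 4-(bromomethyl)phenyl.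

Going by these compounds, how far the true step from the plain phenyl reaches remains open. So does how an ethoxy group, an amine or a carboxylic acid would read in place of the methoxy group.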